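Shortening the phenoxyalkyl chain on the shared core

The source may report more compounds than this note shows. Statements on the series, on what has been measured and on what is new or still open speak of the compounds shown alone.

Compound 1 `O=C(O)c1csc([C@H]2CC[C@@H]3[C@@H](COc4ccc(F)cc4)[C@H](O)C[C@@H]3O2)n1`: > 10000 nM
Compound 2 `Cc1cccc(OC[C@@H]2[C@H]3CC[C@H](c4nc(C(=O)O)cs4)O[C@H]3C[C@H]2O)c1`: > 10000 nM
Compound 3 `O=C(O)c1csc([C@H]2CC[C@@H]3[C@@H](CCCOc4ccccc4)[C@H](O)C[C@@H]3O2)n1`: > 10000 nM

In an assay on HEK293 cells for agonist activity at prostaglandin E2 receptor EP2 subtype (Homo sapiens), read by a beta-galactosidase reporter and beta-arrestin recruitment, with a stated time of 90 min (on this read-out lower numbers stand for an effect already at smaller amounts and higher numbers for an effect only at larger amounts of compound), compound 3 gives > 10000 nM, which is a limit of the assay and not a number. Compound 1 likewise sits at a limit, > 10000 nM. Compound 2 also gives only a limit, > 10000 nM. All three thus rest at the limit of > 10000 nM in this assay, at which 3 of the 3 values shown sit, so the steps a step that the two limits leave unreadable from compound 1 to compound 2, a step that the two limits leave unreadable from compound 1 to compound 3 and a step that the two limits leave unreadable from compound 2 to compound 3 cannot be read in size. Compound 4 `O=C(O)c1csc([C@H]2CC[C@@H]3[C@@H](CCOc4ccccc4)[C@H](O)C[C@@H]3O2)n1` differs from compound 3 by phenoxy in place of phenoxymethyl on a saturated chain carbon, two bonds along the chain from a saturated ring carbon. Among the compounds with values here, no measured step bears readably on this change, so no step beyond the scatter can be expected in this assay, and a limit again seems most likely. Compound 4 is therefore estimated at 15000 nM, between 3000 nM and 60000 nM. The expected step that the limit leaves unreadable from compound 3 to compound 4 is accordingly small.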

Compound 4, half-maximal effective concentration: > 10000 nM
Compound 4: a limit, no number; the forecaster's own chance of this, stated with the estimate: 75%; the middle value lies beyond the limit too.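

Within the data shown here, compound 4 gives > 10000 nM, again a limit of the assay and not a number, so no step from compound 1, compound 2 or compound 3 to compound 4 can be read in size. The compounds shown leave open whether chain length or ring substitution on the shared core changes the half-maximal effective concentration at all.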